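The source may report more compounds than this note shows. Statements on the series, on what has been measured and on what is new or still open speak of the compounds shown alone.

Measured in a functional assay on UACC-62 cells (Homo sapiens) for inhibition, read by sulforhodamine B assay, with a stated time of 48 h, tested at 10 uM; on this read-out higher numbers stand for more inhibition at the one concentration tested (going by the name of the read-out) and lower numbers for less inhibition:

compound 1 `Brc1cn2ccnc2c(-c2ccc3ncn(C4CCCCC4)c3c2)n1`: 19.8%
compound 2 `c1cn2cc(-c3ccsc3)nc(-c3ccc4ncn(C5CCCCC5)c4c3)c2n1`: 18.4%
compound 3 `CC(=O)c1ccc(-c2cn3ccnc3c(-c3ccc4ncn(C5CCCCC5)c4c3)n2)cc1`: 18.5%

Compound 1 gives the highest of the three numbers, but neither neighbour is separated from it: the step of a number 1.3 percentage points lower from compound 1 to compound 3 (within the scatter) and the step of a number 1.4 percentage points lower from compound 1 to compound 2 (within the scatter) both sit inside the scatter, as does a number 0.1 percentage points higher from compound 2 to compound 3 (within the scatter). The three measured compounds are therefore indistinguishable in this assay, and no order among them is claimed.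

Compound 4 `Fc1ccccc1-c1cn2ccnc2c(-c2ccc3ncn(C4CCCCC4)c3c2)n1` differs from compound 1 by 2-fluorophenyl in place of bromo on an aromatic carbon. The two measured steps that bear on this change are those from compound 1 to compound 2 and from compound 1 to compound 3, since each also puts an aromatic ring in place of bromo at the same position on the shared core; both stayed within the scatter. No step beyond the scatter is expected for the 2-fluorophenyl either. Compound 4 is thus estimated at 18.5%, range 9% to 28%, meaning an expected step of a number 1.3 percentage points lower from compound 1 to compound 4 (within the scatter).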

Compound 4, a percentage reported as inhibition, at one concentration (the size of the read-out at that concentration, not a potency): 38.2%
For compound 4 the middle estimate is 19.7 percentage points below the measured one; the whole stated range lies below it.
By their numbers in this assay, from the lowest: compounds 2, 3 and 1 (each within the scatter of the next); then compound 4.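

This position on the shared core does respond in this assay, with 2-fluorophenyl in place of bromo giving a number 18.4 percentage points higher from compound 1 to compound 4 (beyond the scatter). The earlier agreement among bromo, thiophen-3-yl and 4-acetylphenyl therefore does not extend to every group placed here. Carrying an aromatic ring at this position is not enough for the step, as one aromatic ring in place of another also gives a number 19.7 percentage points higher from compound 3 to compound 4 (beyond the scatter) and a number 19.8 percentage points higher from compound 2 to compound 4 (beyond the scatter). Nothing available here bears on why the 2-fluorophenyl stands apart.

Open, as far as these compounds go, is whether a plain phenyl would match the 2-fluorophenyl, so the share of the fluorine in the step cannot be told. Also open, from the compounds shown here alone, is how an amine or a carboxylic acid on that ring would read, and whether this single-concentration number reflects a difference in potency.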